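Oxime ether series: propyl to phenyl on the oxygen

This account rests on a few compounds, and the source may have more. Where it says the series, first, only, none or still open, it means among the compounds named here.

Measured compounds:
compound 1 `CCO/N=C/Nc1cc(Cl)c(OCOC)c(Cl)c1` gives 3.7 in a physicochemical assay for lipophilicity, measured as octanol-water partition; on this read-out lower numbers stand for lower lipophilicity and higher numbers for higher lipophilicity
compound 2 `C#CCc1c(Cl)cc(N/C=N/OCCC)cc1Cl` gives 4

Compound 2 holds the higher of the two numbers shown, and compound 1 sits close to it, within the scatter, so the two compounds cannot be ordered against each other. The unmeasured compound 3 `C#CCc1c(Cl)cc(N/C=N/Oc2ccccc2)cc1Cl` differs from compound 2 in one place: phenyl in place of propyl on an oxygen. Among the measured compounds shown here, no step between measured compounds covers this exchange, so the expectation rests on the change alone. A moderate rise in this assay beyond the scatter is expected, a step of a number 0.50 log units higher from compound 2 to compound 3 (beyond the scatter). Compound 3 is estimated at 4.5, in the range 4 to 5.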

Compound 3, partition coefficient: 4.4
Compound 3: the middle estimate sits 0.10 log units above what was measured; the range from low to high includes it.
By their numbers in this assay, from the lowest: compounds 1 and 2 (each within the scatter of the next); then compound 3.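

Among the compounds shown here, this is the first exchange that can be read in one place: on an oxygen whose other neighbours are double-bonded nitrogen, phenyl in place of propyl gives in this assay a number 0.40 log units higher from compound 2 to compound 3 (beyond the scatter), so the read-out responds to a change at this position. Nothing available accounts for the size of this step.

On these data alone, how a longer chain such as hexyl, or a chain carrying an amine or a carboxylic acid, would read on this oxygen stays open. So does whether the same exchange gives a similar step on the core of compound 1.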